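Benzoxazole swap on the distal ring of a phenoxyacetic acid

A few compounds are considered here, and "the series" means these few. Any claim that something is new, unique, unknown or untested is made for them only; others in the source may bear on it.

Compound 2 `COc1ccc(C)c(-c2cccc(COc3ccc(OCC(=O)O)c(F)c3)c2)c1` gives 260 nM in a functional assay on CHO cells for agonist activity at Free fatty acid receptor 1 (Homo sapiens), read by FLIPR and calcium flux (on this read-out higher numbers stand for an effect only at larger amounts of compound and lower numbers for an effect already at smaller amounts), and holds the lowest of the two numbers seen so far. Among the measured compounds shown here, its nearest neighbour is compound 1 `Cc1ccc(OCC2CCCCC2)cc1-c1cccc(COc2ccc(OCC(=O)O)c(F)c2)c1`, which in this assay gives 910 nM; the only measured step, a 3.5-fold lower number from compound 1 to compound 2 (0.54 log units; beyond the scatter), replaces cyclohexyl by hydrogen on a saturated chain carbon bound to an oxygen on an aromatic ring.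

Compound 3 `O=C(O)COc1ccc(OCc2cccc(-c3ccc4ncoc4c3)c2)cc1F` is not yet measured. It differs from compound 2 by 1,3-benzoxazol-6-yl in place of 5-methoxy-2-methylphenyl on an aromatic carbon. The change sits on an aromatic carbon of a six-membered aromatic ring of carbon only, meta to a large group, and exchanges the whole distal aryl rather than trimming an ether substituent.

For the measured compounds named here, no measured step bears on an exchange of this kind; the step from compound 1 to compound 2 concerns a different part of the molecule and offers no guide to the direction. With the shared core and the acid untouched, the expectation for compound 3 is a step near the scatter, a 1.2-fold higher number from compound 2 to compound 3 (0.09 log units; within the scatter), with wide uncertainty. Compound 3 is therefore estimated at 320 nM in this assay, within 80 nM to 1300 nM.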

Compound 3, half-maximal effective concentration: 3240 nM
Compound 3: the middle estimate sits 10-fold (1.01 log units) below what was measured, and the stated range ends below it.
By their numbers in this assay, from the lowest: compound 2; then compound 1; then compound 3.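

The distal aryl, on an aromatic carbon meta to a large group, is sensitive to exchange in this assay: 1,3-benzoxazol-6-yl in place of 5-methoxy-2-methylphenyl gives a 12-fold higher number from compound 2 to compound 3 (1.10 log units; beyond the scatter), a large step. The two groups have the same count of heavy atoms, 9, and neither carries a net charge, so matching these counts did not preserve the number; what differs is the added five-membered aromatic ring with 2 hetero atoms, the extra hydrogen-bond acceptor and the absence of the methoxy and methyl groups. No measurement available here accounts for the size of this step.

Because the exchange alters the ring system and both substituents in one move, the compounds shown cannot assign the step to any one of these differences, nor tell whether the methoxy or the methyl group of 5-methoxy-2-methylphenyl matters more. Open too, going by these compounds, is how the number would respond to a simpler distal group, such as an unsubstituted phenyl or a pyridine ring, or to a 1,3-benzothiazol-6-yl group carrying sulfur in place of the benzoxazole oxygen.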